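Same Ring Swap, Second Core: Forecasting Compound 4

The source may report more compounds than this note shows. Statements on the series, on what has been measured and on what is new or still open speak of the compounds shown alone.

Measured compounds:
Compound 1 `Cc1ccc(C)c(C(Nc2ccccn2)c2ccc3cccnc3c2O)c1`, in an assay for inhibition of protein disulfide-isomerase (Homo sapiens), with a stated time of 1 h (a lower number here means a stronger inhibitor, a higher number a weaker inhibitor), compound 1 gives 730 nM.
Compound 2 `CCc1ccc(C(Nc2ccccn2)c2ccc3cccnc3c2O)cc1`, in this assay compound 2 gives 170 nM.
Compound 3 `CCc1ccc(C(Nc2cc(C)ccn2)c2ccc3cccnc3c2O)cc1`, in this assay compound 3 gives 5390 nM.

Two changes have been measured. Going from compound 2 to compound 1 the change is 2,5-dimethylphenyl in place of 4-ethylphenyl on a saturated chain carbon bound to an aromatic carbon and a nitrogen on an aromatic ring, and it gave a 4.3-fold higher number from compound 2 to compound 1 (0.63 log units; beyond the scatter). Going from compound 2 to compound 3 the change is methyl in place of hydrogen on an aromatic carbon, and it gave a 32-fold higher number from compound 2 to compound 3 (1.50 log units; beyond the scatter), the largest step seen among these three compounds; compound 3 thus has the highest number of the three, and its steps to compound 1 and to compound 2 both lie beyond the scatter.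

Compound 4 `Cc1ccnc(NC(c2cc(C)ccc2C)c2ccc3cccnc3c2O)c1` has not yet been measured. It differs from compound 3 by 2,5-dimethylphenyl in place of 4-ethylphenyl on a saturated chain carbon bound to an aromatic carbon and a nitrogen on an aromatic ring. The place description is the same word for word as for the change from compound 2 to compound 1, so this is the same change, now made on the core of compound 3 rather than the core of compound 2; the two cores differ by methyl in place of hydrogen on an aromatic carbon.

Among the measured compounds shown here, the only guide is the measured pair, where the change gave a 4.3-fold higher number from compound 2 to compound 1 (0.63 log units; beyond the scatter). If it behaves alike on the second core, compound 4 is expected to show a 3.7-fold higher number from compound 3 to compound 4 (0.57 log units; beyond the scatter). Because compound 3 already gives 5390 nM, compound 4 is estimated at 20000 nM, within a range from 6000 nM to 70000 nM.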

Compound 4, half-maximal inhibitory concentration: > 40000 nM
Compound 4: no number, only a limit; the forecaster's own chance of this, stated with the estimate: 30%; at least 2.0-fold (0.30 log units) between middle value and limit.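

In this assay compound 4 gives > 40000 nM, which is a limit of the assay and not a number. Going by these compounds, putting 2,5-dimethylphenyl in place of 4-ethylphenyl raised the number on both cores, with an at least 7.4-fold higher number from compound 3 to compound 4 (0.87 log units; beyond the scatter) on the second core, so the direction of this change carried over in this one further case, but whether its size carried over stays unknown: the same change on two cores in this assay, a 4.3-fold higher number (0.63 log units; beyond the scatter) from compound 2 to compound 1 and an at least 7.4-fold higher number (0.87 log units; beyond the scatter) from compound 3 to compound 4; the limit leaves it open whether they differ. Adding the methyl on an aromatic carbon also raised the number on both cores, here with an at least 54-fold higher number from compound 1 to compound 4 (1.73 log units; beyond the scatter), and again the comparison of sizes remains unsettled: the same change on two cores in this assay, a 32-fold higher number (1.50 log units; beyond the scatter) from compound 2 to compound 3 and an at least 54-fold higher number (1.73 log units; beyond the scatter) from compound 1 to compound 4; the limit leaves it open whether they differ.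

The compounds shown leave open how far compound 4 lies past its limit, so they cannot tell whether the two changes simply add up or together do more than that. They also leave open how an amine or a longer chain in place of 4-ethylphenyl would behave on the core of compound 3, and whether a chlorine or a methoxy group in place of the added methyl would raise the number as much.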